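Exchanging one phenyl group on compound 3

The source may report more compounds than this note shows. Statements on the series, on what has been measured and on what is new or still open speak of the compounds shown alone.

Results so far in a functional assay on HepG2 cells (Homo sapiens) for antiproliferative activity, read by MTT assay, with a stated time of 72 h; a lower number here means a stronger inhibitor, a higher number a weaker inhibitor
compound 1 `COc1ccc(OCCCON2C(N)=NC(N)=NC23CCOCC3)cc1` gives "not determined" (no result reported)
compound 2 `Cc1cc(C)cc(OCCCON2C(N)=NC(N)=NC23CCOCC3)c1` gives 680 nM
compound 3 `NC1=NC2(CCOCC2)N(OCCCOc2ccc(Cl)c(Cl)c2)C(N)=N1` gives 380 nM

Among the compounds with values here, only two numbers exist so far, and the gap between them is a 1.8-fold lower number from compound 2 to compound 3 (0.25 log units; within the scatter) and so compound 3 stands level with its one measured neighbour, while compound 1 has no result to compare. The next compound, compound 4 `NC1=NC2(CCOCC2)N(OCCCOc2cccc(Br)c2)C(N)=N1`, has not been measured. It differs from compound 3 in one place, on an oxygen on a saturated carbon, and the change is 3-bromophenyl in place of 3,4-dichlorophenyl on an oxygen on a saturated carbon with the rest of the molecule untouched. Within the data shown here, one measured step bears on this. It exchanged the phenyl group at that same place: a 1.8-fold lower number from compound 2 to compound 3 (0.25 log units; within the scatter) and that is no larger than repeat measurements can differ by chance. Among the measured compounds shown here, no measured compound yet carries a bromine, so this is a thin basis. The expected step is a 1.2-fold higher number from compound 3 to compound 4 (0.07 log units; within the scatter) and no shift beyond the scatter is expected in this assay here. For compound 4 the estimated value is 450 nM within an expected range (180 nM to 1100 nM).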

Compound 4, half-maximal inhibitory concentration: 320 nM
For compound 4 the middle estimate is 1.4-fold (0.15 log units) above the measured one, and the stated range covers the measured number.
By their numbers in this assay, from the lowest: compounds 4, 3 and 2 (each within the scatter of the next, the first and the last beyond it).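

In this assay the exchange of 3,4-dichlorophenyl for 3-bromophenyl gives a 1.2-fold lower number from compound 3 to compound 4 (0.07 log units; within the scatter), so at this place a ring with a single bromine cannot be told apart from one with two chlorines. Against 3,5-dimethylphenyl, the same 3-bromophenyl gives a 2.1-fold lower number from compound 2 to compound 4 (0.33 log units; beyond the scatter), the first step at this place to pass the scatter, though only modestly, while compound 3 stays within the scatter of both neighbours. Nothing available explains why these rings compare as they do.

Compound 1 has no result, so steps to it cannot be read. Still open, going by these compounds, is whether this place would accept a phenyl ring carrying an amine or a carboxylic acid, a plain unsubstituted phenyl, or a longer chain leading to the ring.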